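Swapping a Chain for an Aromatic Ring on the Carbonyl

The source may hold more compounds than are shown below. What is called first, only, known or untested is meant among the compounds shown, and "the series" means these compounds.

Compound 1 `CC(=O)CCCCC(=O)N1CCN(c2nccc(Oc3cccc(C)c3)n2)CC1`: 0%
Compound 2 `COC[C@@H]1CCCN1C(=O)C1CCCN1c1cc(Nc2cccc(Br)c2)ncn1`: 0%

In an assay on isolated protein for inhibition of RAC-alpha serine/threonine-protein kinase (Homo sapiens), read by HTRF, tested at 10 uM (a lower number here means less inhibition, a higher number more inhibition at the concentration tested (going by the name of the read-out)), compound 1 gives 0%. Compound 2 gives 0%, so compound 1 stands level with compound 2 at the digits shown, within the scatter. Compound 3 `Cc1cccc(Oc2ccnc(N3CCN(C(=O)c4c(C)noc4C)CC3)n2)c1` is not yet measured. It differs from compound 1 in one place: 3,5-dimethyl-1,2-oxazol-4-yl in place of 4-acetylbutyl on a carbonyl carbon. For the measured compounds named here, no measured pair shows a step of this kind, so the only guide is that both measured compounds show no inhibition. The step from compound 1 to compound 3 is expected to be a number 5 percentage points higher from compound 1 to compound 3 (within the scatter), that is none beyond the scatter. Compound 3 is estimated at 5%, between -10% and 25%.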

Compound 3, a percentage reported as inhibition, at one concentration (the size of the read-out at that concentration, not a potency): 1%
For compound 3 the middle estimate is 4 percentage points above the measured one; low and high end bracket the measured number.
By their numbers in this assay, from the lowest: compounds 1, 2 and 3 (each within the scatter of the next).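

In this assay, for the compounds shown here, 3,5-dimethyl-1,2-oxazol-4-yl in place of 4-acetylbutyl on the carbonyl carbon gives a number 1 percentage points higher from compound 1 to compound 3 (within the scatter), the first step that can be read at this position. An open chain and a five-membered aromatic ring thus read alike here, with both compounds showing essentially no inhibition. No measurement available explains this flat result. On these data alone, whether a phenyl ring or a chain ending in a carboxylic acid on this carbonyl would give real inhibition stays open. So does whether the core of compound 1 can give any inhibition at all.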